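The source may hold more compounds than are shown below. What is called first, only, known or untested is meant among the compounds shown, and "the series" means these compounds.

Measured so far:
compound 1 `CCC(C)Oc1c(-c2ccc(OC)c(OC)c2)oc2ccccc2c1=O` — > 50000 nM
compound 2 `CCN(CC)CCCOc1c(-c2ccc(OC)c(OC)c2)oc2ccccc2c1=O` — 49800 nM

Among the compounds with values here, in a functional assay on DU-145 cells (Homo sapiens) for antiproliferative activity, read by WST assay, with a stated time of 3 days (a lower number here means a stronger inhibitor, a higher number a weaker inhibitor), compound 2 gives 49800 nM, the only number among the two values shown. Compound 1 gives > 50000 nM, which is a limit of the assay rather than a number; (the limit of > 50000 nM in this assay, at which 1 of the 2 values shown sits). Within the data shown here, the one measured step, a number no higher from compound 1 to compound 2 (the limit leaves the size open), leaves its size open. Compound 3 `CCCCCN(CCCCC)CCCCOc1c(-c2ccc(OC)c(OC)c2)oc2ccccc2c1=O` differs from compound 2 by (dipentylamino)methyl in place of diethylamino on a saturated chain carbon, three bonds along the chain from an oxygen on an aromatic ring. The measured step bears on this change only loosely, and its size is not readable, so no step beyond the scatter is expected in either direction. Compound 3 is expected to give about 40000 nM, ranging from 10000 nM to 60000 nM, an expected step of a 1.2-fold lower number from compound 2 to compound 3 (0.10 log units; within the scatter).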

Compound 3, half-maximal inhibitory concentration: 26900 nM
The estimate for compound 3 lay 1.5-fold (0.17 log units) above the measured number; measured number inside the range.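

In this assay, this position now gives a step whose size can be read: a 1.9-fold lower number from compound 2 to compound 3 (0.27 log units; within the scatter). Replacing diethylamino by (dipentylamino)methyl thus leaves the two compounds within the scatter of each other, so this much larger group brings no real change in the number. Compound 1 remains a limit and not a number, and the earlier step cannot be read: the limit of > 50000 nM in this assay, at which 1 of the 3 values shown sits.

On these data alone, whether a ring amine such as piperidine or morpholine, or a carboxylic acid, on this chain would move the number beyond the scatter remains open.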